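Methoxy on two cores: tolerance on macrophage cells

The source may hold more compounds than are shown below. What is called first, only, known or untested is meant among the compounds shown, and "the series" means these compounds.

Compound 1 `O=C(Nc1ccc(Cl)cc1F)c1ccccc1OCc1ccc(F)cc1F` and compound 2 `COc1ccc(C(=O)Nc2ccc(Cl)cc2F)c(OCc2ccc(F)cc2F)c1` share one core; compound 3 `O=c1oc2ccccc2c(=O)n1-c1ccc(F)cc1F` is built on a different core, and compound 4 `COc1ccc2c(=O)n(-c3ccc(F)cc3F)c(=O)oc2c1` is its not yet measured methoxy analogue. The difference between the two cores is not broken down here.

In an ADME assay on RAW264.7 cells (Mus musculus) for cytotoxicity, read by MTT assay, with a stated time of 24 h (a higher number here means that more compound is tolerated, a lower number that less compound is tolerated), compound 1 gives > 40000 nM, which is a limit of the assay and not a number. In this assay compound 2 gives > 40000 nM, again a limit. The change between them is methoxy in place of hydrogen on an aromatic carbon and it yields a step that the two limits leave unreadable from compound 1 to compound 2.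

In this assay compound 3 gives > 40000 nM, also a limit. Every value shown so far sits at the limit of > 40000 nM in this assay, at which 3 of the 3 values shown sit.

The change in hand is methoxy in place of hydrogen on an aromatic carbon. For the measured compounds named here, it is the same kind of change as the one from compound 1 to compound 2, not the same: there the place is "meta to a large group; para to a large group", whereas here the ring is "part of a fused or bridged system of two rings; meta to a fused ring; para to a fused ring".

The step from compound 3 to compound 4 in this assay is estimated as a step that the limit leaves unreadable from compound 3 to compound 4, an expectation resting on compound 1 and compound 2 both sitting at the limit of > 40000 nM in this assay, at which 3 of the 3 values shown sit, on either side of the same kind of change, so that no readable size is available. Compound 4 is expected to give 60000 nM in this assay, with a range estimated from 30000 nM to 150000 nM, and a strong chance that only a limit is reported once more.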

Compound 4, half-maximal cytotoxic concentration: > 40000 nM
Compound 4 was reported as a limit; the forecaster's own chance of this, stated with the estimate: 85%; the middle value lies beyond the limit too.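

No size can be read for the step from compound 3 to compound 4 in this assay, because both compounds, like compound 1 and compound 2, stand at a limit of the assay and not at a number: the limit of > 40000 nM in this assay, at which 4 of the 4 values shown sit.

The compounds shown leave open at what concentration any of the four reduces tolerance, and whether methoxy in place of hydrogen on an aromatic carbon shifts that concentration on either core.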